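The source may hold more compounds than are shown below. What is called first, only, known or untested is meant among the compounds shown, and "the series" means these compounds.

In a functional assay on MCF7 cells (Homo sapiens) for antiproliferative activity, read by sulforhodamine B assay, with a stated time of 3 days (on this read-out lower numbers stand for stronger inhibition and higher numbers for weaker inhibition), compound 1 (`C=CCOc1ncnc2[nH]cnc12`) gives 44700 nM, compound 2 (`c1ccc2c(c1)COC(n1cnc3c(OCC4CCCCC4)ncnc31)CO2`) gives 11600 nM and compound 3 (`c1ccc(Oc2ncnc3c2ncn3C2COc3ccccc3CO2)cc1`) gives 24700 nM. Compound 3 has the second highest of these three numbers, yet it lies within the usual scatter of compound 1, and only compound 2 stands clearly lower.

Compound 4 (`Clc1ccc(Sc2ncnc3c2ncn3C2COc3ccccc3CO2)c(Cl)c1`) has not yet been measured. It carries (2,4-dichlorophenyl)sulfanyl in place of phenoxy on an aromatic carbon of the shared core: (2,4-dichlorophenyl)sulfanyl in place of phenoxy on an aromatic carbon.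

Among the measured compounds shown here, one measured step bears on this change: a 2.1-fold higher number from compound 2 to compound 3 (0.33 log units; beyond the scatter). That step swapped one group for another at the same aromatic carbon, and its size was modest, just beyond the scatter. For the measured compounds named here, no measured compound carries sulfur or chlorine, so the data give no direct guide to the incoming group. A large jump therefore seems unlikely, and the direction is only a loose guess.

What is expected in this assay is a small step toward a lower number, estimated as a 2.1-fold lower number from compound 3 to compound 4 (0.31 log units; beyond the scatter). For compound 4 the expected value is 12000 nM, with an estimated range from 4000 nM to 35000 nM.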

Compound 4, half-maximal inhibitory concentration: 12000 nM
For compound 4 middle estimate and measured number coincide at the digits printed; low and high end bracket the measured number.
By their numbers in this assay, from the lowest: compounds 2 and 4 (each within the scatter of the next); then compounds 3 and 1 (each within the scatter of the next).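

In this assay, among the compounds shown here, the aromatic carbon of the shared core proves sensitive to more than the one exchange seen before: replacing phenoxy with (2,4-dichlorophenyl)sulfanyl gives a 2.1-fold lower number from compound 3 to compound 4 (0.31 log units; beyond the scatter) and so moves the number the opposite way from the earlier step, though the size is again modest. The comparison with cyclohexylmethoxy gives a 1.0-fold higher number from compound 2 to compound 4 (0.01 log units; within the scatter) and lies within the scatter, so at this carbon an aromatic group joined through sulfur and a saturated ring joined through an oxygen and a carbon cannot be told apart, even though phenoxy gave a clearly higher number than cyclohexylmethoxy. The new step changes the linking atom and adds two chlorines at once, and nothing measured here accounts for the shift.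

The compounds shown leave open how a plain phenylsulfanyl group or a 2,4-dichlorophenoxy group would read at this carbon, and these two would help separate the part played by the sulfur from that of the chlorines. How an amine at the same carbon, or a longer chain on the sulfur, would read also remains an open question.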